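The source may hold more compounds than are shown below. What is called first, only, known or untested is meant among the compounds shown, and "the series" means these compounds.

Measured so far in a functional assay on HepG2 cells (Homo sapiens) for inhibition, read by MTT assay, with a stated time of 72 h; on this read-out higher numbers stand for weaker inhibition and lower numbers for stronger inhibition:
Compound 1 `CNc1nc(C)c(C(=O)N/N=C/c2cccc(C(F)(F)F)c2)s1` gives > 100 ug/mL, which is a limit of the assay and not a number (the limit of > 100 ug/mL in this assay, at which 1 of the 3 values shown sits).
Compound 2 `CN(C(=O)NC(=O)c1c(F)cccc1F)c1nc(C(F)(F)F)c(C(=O)N/N=C/c2cccc(C(F)(F)F)c2)s1` gives 27.9 ug/mL.
Compound 3 `Cc1nc(N(C)C(=O)NC(=O)c2c(F)cccc2F)sc1C(=O)N/N=C/c1cccc(C(F)(F)F)c1` gives 31.6 ug/mL.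

Compound 3 and compound 2 differ in one place: trifluoromethyl in place of methyl on an aromatic carbon. That change gave a 1.1-fold lower number from compound 3 to compound 2 (0.05 log units; within the scatter). Compound 4 `CNc1nc(C(F)(F)F)c(C(=O)N/N=C/c2cccc(C(F)(F)F)c2)s1` is not yet measured and differs from compound 1 by trifluoromethyl in place of methyl on an aromatic carbon. This is the same kind of change, though the surroundings differ: in compound 3 the place lies two ring bonds from the ring atom that bears a large group, in compound 1 two ring bonds from the ring atom that bears a methylamino group (2 heavy atoms). How the core of compound 1 differs from that of compound 3 is not broken down here. The expectation for compound 4 rests on the step of a 1.1-fold lower number from compound 3 to compound 2 (0.05 log units; within the scatter), which was within the scatter. Compound 4 is expected to show a step that the limit leaves unreadable from compound 1 to compound 4. Compound 4 is estimated at 150 ug/mL, between 60 ug/mL and 400 ug/mL, and is likely to be reported again only as a limit.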

Compound 4, half-maximal inhibitory concentration: > 100 ug/mL
Compound 4: no number, only a limit; the forecaster's own chance of this, stated with the estimate: 75%; the middle value does not contradict the limit.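

Compound 1 and compound 4 both sit at a limit of the assay rather than at a number, so no step between them can be read: the limit of > 100 ug/mL in this assay, at which 2 of the 4 values shown sit.

On these data alone, whether trifluoromethyl in place of methyl changes the result on the core of compound 1 stays open.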